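Amide aryl swap on the shared core: compound 3

The source may hold more compounds than are shown below. What is called first, only, known or untested is meant among the compounds shown, and "the series" means these compounds.

Compound 2 `CS(=O)(=O)c1ccc(NC(=O)c2cn(Cc3c(F)cccc3F)c3ccc(=O)[nH]c3c2=O)cc1` gives 27 nM in an in vitro assay on Sf21 cells for inhibition of high affinity 3',5'-cyclic-AMP phosphodiesterase 7A (Homo sapiens), read by scintillation proximity assay, with a stated time of 30 min (a lower number here means a stronger inhibitor, a higher number a weaker inhibitor), the lowest of the two numbers at hand; compound 1 `N#Cc1cccc(NC(=O)c2cn(Cc3c(F)cccc3F)c3ccc(=O)[nH]c3c2=O)c1` gives 1070 nM. Among the compounds with values here, the only measured step at this position, a 40-fold lower number from compound 1 to compound 2 (1.60 log units; beyond the scatter), shows that the aryl group on the amide-type nitrogen matters greatly. Compound 3 `COc1cc(NC(=O)c2cn(Cc3c(F)cccc3F)c3ccc(=O)[nH]c3c2=O)cc(OC)c1` makes the change (3,5-dimethoxyphenyl in place of 4-(methylsulfonyl)phenyl on an amide-type nitrogen). Within the data shown here, no measured step covers 3,5-dimethoxyphenyl itself, so the direction rests on the one step available; leaving the 4-(methylsulfonyl)phenyl of compound 2 is expected to weaken binding in this assay, giving an 11-fold higher number from compound 2 to compound 3 (1.05 log units; beyond the scatter). Compound 3 is therefore estimated at 300 nM, with a range of 60 nM to 1500 nM.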

Compound 3, half-maximal inhibitory concentration: 212 nM
Compound 3: the middle estimate sits 1.4-fold (0.15 log units) above what was measured, within the range that was stated.
By their numbers in this assay, from the lowest: compound 2; then compound 3; then compound 1.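

In this assay the amide aryl position now gives a graded response rather than one large step: 3,5-dimethoxyphenyl loses to 4-(methylsulfonyl)phenyl, with a 7.9-fold higher number from compound 2 to compound 3 (0.89 log units; beyond the scatter), yet improves on 3-cyanophenyl, with a 5.0-fold lower number from compound 1 to compound 3 (0.70 log units; beyond the scatter). The heavy-atom and hydrogen-bond acceptor counts match between 4-(methylsulfonyl)phenyl and 3,5-dimethoxyphenyl, so these counts do not separate compound 2 from compound 3. No measurement shown explains either step. Still open, on these data alone, is whether a sulfonamide or a carboxylic acid in place of the methylsulfonyl group would keep the level of compound 2.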